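The compounds below may be only part of what the source reports. "The series", "measured", "known", "first", "only" and "open" are said of these compounds alone.

Measured so far in a physicochemical assay for solubility, in phosphate buffer, with a stated time of 18 h; a higher number here means a more soluble compound, a lower number a less soluble compound
compound 1 `CSc1nc(C(C)(C)C)nc2nc(N)c(C#N)c(N)c12` gives 14000 nM
compound 2 `Cc1nc(C(C)(C)C)nc2nc(N)c(C#N)c(N)c12` gives 37000 nM
compound 3 `CC(C)(C)c1nc(-c2ccccc2)c2c(N)c(C#N)c(N)nc2n1` gives 4000 nM

Compound 3 stands lowest of the three, and both gaps lie beyond the scatter. For the measured compounds named here, compound 4 `CC(C)(C)c1nc(-c2ncc[nH]2)c2c(N)c(C#N)c(N)nc2n1` changes one group of compound 3 (1H-imidazol-2-yl in place of phenyl on an aromatic carbon), and no measured compound carries 1H-imidazol-2-yl. Going by the values given here, two measured steps bear on this change, since both bring in phenyl at the same place. The steps of a 3.5-fold lower number from compound 1 to compound 3 (0.54 log units; beyond the scatter) and a 9.3-fold lower number from compound 2 to compound 3 (0.97 log units; beyond the scatter) are both modest. Losing phenyl is therefore expected to give a modest rise, though neither step shows what the incoming group does. The expected step is a 2.5-fold higher number from compound 3 to compound 4 (0.40 log units; beyond the scatter) in this assay on this estimate. Compound 4 is estimated at 10000 nM with an expected range of 3000 nM to 35000 nM for now.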

Compound 4, solubility: < 1000 nM
Compound 4: no number, only a limit (the forecaster's own chance of this, stated with the estimate: 5%); middle value at least 10-fold (1.00 log units) away from the limit.
By their numbers in this assay, from the lowest: compound 3; then compound 1; then compound 2. At a limit, below all of these: compound 4.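

In this assay compound 4 carries a limit, not a number: the limit of < 1000 nM in this assay, at which 1 of the 4 values shown sits. Losing phenyl therefore does not by itself raise the number at this position, since 1H-imidazol-2-yl gives an at least 4.0-fold lower number from compound 3 to compound 4 (0.60 log units; beyond the scatter). Against the smaller groups the change is larger, with an at least 37-fold lower number from compound 2 to compound 4 (1.56 log units; beyond the scatter) and an at least 14-fold lower number from compound 1 to compound 4 (1.14 log units; beyond the scatter).

As far as these compounds go, how far compound 4 lies past its limit stays open, as does which feature of 1H-imidazol-2-yl matters. Also open, from the compounds shown here alone, is what an amine or a carboxylic acid would give on this aromatic carbon.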